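Nitro in place of chloro, judged from limits alone

A few compounds are considered here, and "the series" means these few. Any claim that something is new, unique, unknown or untested is made for them only; others in the source may bear on it.

In a functional assay on L1210 cells (Mus musculus) for inhibition (on this read-out lower numbers stand for stronger inhibition and higher numbers for weaker inhibition), compound 1 `C#CCN(Cc1ccc2nc(C)nc(O)c2c1)c1ccccc1` gives > 6500 nM, which is a limit. Compound 2 `C#CCN(Cc1ccc2nc(C)nc(O)c2c1)c1cccc(C)c1` gives > 5000 nM, also a limit. Compound 3 `C#CCN(Cc1ccc2nc(C)nc(O)c2c1)c1ccc(Cl)cc1` gives > 4000 nM, again a limit, so no number fixes where it stands. Compound 4 `C#CCN(Cc1ccc2nc(C)nc(O)c2c1)c1ccc([N+](=O)[O-])cc1` carries nitro in place of chloro on an aromatic carbon, para to a large group: nitro in place of chloro on an aromatic carbon. Going by the values given here, three measured steps bear on this change: a step that the two limits leave unreadable from compound 1 to compound 2, a step that the two limits leave unreadable from compound 1 to compound 3 and a step that the two limits leave unreadable from compound 2 to compound 3. None has a readable size, so they offer no scale and no direction. No step beyond the scatter is therefore expected, and the estimated step is a step that the limit leaves unreadable from compound 3 to compound 4. For compound 4 the estimated value is 5000 nM, with an expected range from 1500 nM to 15000 nM.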

Compound 4, half-maximal inhibitory concentration: 4700 nM
For compound 4 the middle estimate is 1.1-fold (0.03 log units) above the measured one; the measured number falls inside the stated range.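

In this assay compound 4 gives 4700 nM, the only number among the compounds shown that is not a limit. Nitro on this aromatic carbon thus yields the one readable comparison, an at least 1.3-fold lower number from compound 1 to compound 4 (0.14 log units; that floor lies within the scatter), for nitro in place of hydrogen. The step for nitro in place of chloro cannot be read because compound 3 is known only as a limit: the limit of > 4000 nM in this assay, at which 1 of the 4 values shown sits.

On these data alone, how far compound 3 lies from compound 4 stays open. So does how an amine or a carboxylic acid on this aromatic carbon would read in this assay.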